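This account rests on a few compounds, and the source may have more. Where it says the series, first, only, none or still open, it means among the compounds named here.

Compound 1 `Cn1cncc1C(OCc1ccc(C#N)cc1C#CC1(O)CCCCC1)c1ccc(C#N)cc1` gives 1.93 nM in a functional assay on NIH3T3 cells (Mus musculus); on this read-out lower numbers stand for an effect already at smaller amounts and higher numbers for an effect only at larger amounts of compound. Among the three compounds measured so far it holds the second highest number. Compound 2 `Cn1cncc1C(OCc1ccc(C#N)cc1/C=C/c1ccccn1)c1ccc(C#N)cc1` gives 23.1 nM in this assay, and compound 3 `Cn1cncc1C(OCc1ccc(C#N)cc1C#Cc1ccccc1)c1ccc(C#N)cc1` gives 0.1 nM. The step of a 12-fold higher number from compound 1 to compound 2 (1.08 log units; beyond the scatter) accompanied 2-(pyridin-2-yl)ethenyl in place of 2-(1-hydroxycyclohexyl)ethynyl on an aromatic carbon, while a 19-fold lower number from compound 1 to compound 3 (1.29 log units; beyond the scatter) accompanied phenyl in place of 1-hydroxycyclohexyl on a triple-bonded carbon; between those two, a 230-fold lower number from compound 2 to compound 3 (2.36 log units; beyond the scatter).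

Compound 4 `Cn1cncc1C(OCc1ccc(C#N)cc1-c1ccc(C#N)cc1)c1ccc(C#N)cc1` has not been measured. It differs from compound 1 in one place: 4-cyanophenyl in place of 2-(1-hydroxycyclohexyl)ethynyl on an aromatic carbon. Both measured steps bear on it. An aromatic ring enters, as in the large gain of compound 3, yet the triple bond that carries the ring in compound 3 is not kept in compound 4, and compound 2, also without that arrangement, gave the highest number. One therefore expects a moderately lower number for compound 4, a 2.1-fold lower number from compound 1 to compound 4 (0.33 log units; beyond the scatter). Compound 4 is estimated at 0.9 nM, with a range from 0.2 nM to 5 nM.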

Compound 4, half-maximal effective concentration: < 0.1 nM
Compound 4 gave a limit, no number (the forecaster's own chance of this, stated with the estimate: 3%); at least 9.0-fold (0.95 log units) between middle value and limit.
By their numbers in this assay, from the lowest: compound 3; then compound 1; then compound 2.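

In this assay compound 4 gives a limit and not a number: the limit of < 0.1 nM in this assay, at which 1 of the 4 values shown sits. Even so, the limit shows that this aromatic carbon does not need a triple bond to carry an aromatic ring, since directly attached 4-cyanophenyl in place of 2-(1-hydroxycyclohexyl)ethynyl accompanied an at least 19-fold lower number from compound 1 to compound 4 (1.28 log units; beyond the scatter), and in place of 2-(pyridin-2-yl)ethenyl it accompanied an at least 230-fold lower number from compound 2 to compound 4 (2.36 log units; beyond the scatter). The remaining step, a number no higher from compound 3 to compound 4 (the limit leaves the size open), cannot be read.

The compounds shown leave open how much of this result belongs to the nitrile of 4-cyanophenyl and how much to the ring itself, a question that a plain phenyl or a 4-aminophenyl group on this carbon would address. They also do not tell how far the true value of compound 4 lies from its limit.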